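Trifluoromethyl for chloro on the urea aryl of compound 1

A few compounds are considered here, and "the series" means these few. Any claim that something is new, unique, unknown or untested is made for them only; others in the source may bear on it.

Measured so far in a functional assay on SNB-75 cells (Homo sapiens) for inhibition, read by sulforhodamine B assay, with a stated time of 48 h; on this read-out lower numbers stand for stronger inhibition of growth and higher numbers for weaker inhibition of growth:
- compound 1 `COc1cc(-c2nn(-c3cccc(NC(=O)Nc4ccc(Cl)c(Cl)c4)c3)cc2-c2ccncc2)ccc1Cl`, giving 5170 nM
- compound 2 `O=C(Nc1cccc(-n2cc(-c3ccncc3)c(-c3ccc(Cl)c(O)c3)n2)c1)Nc1ccc(Cl)c(Cl)c1`, giving 12200 nM

Among the measured compounds shown here, compound 1 carries the lowest of the two numbers; the only neighbour is compound 2, reached by a 2.4-fold higher number from compound 1 to compound 2 (0.37 log units; beyond the scatter), a change of the methyl on the aromatic oxygen and not of the urea aryl.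

Compound 3 `COc1cc(-c2nn(-c3cccc(NC(=O)Nc4ccc(Cl)c(C(F)(F)F)c4)c3)cc2-c2ccncc2)ccc1Cl` differs from compound 1 by trifluoromethyl in place of chloro on an aromatic carbon. For the measured compounds named here, no measured step in this assay touches that position, so the single step known, from compound 1 to compound 2, gives no direct guide; it only shows that one small change on the shared core moved the number modestly. With nothing bearing on the urea aryl, the step expected from compound 1 to compound 3 is a 1.1-fold lower number from compound 1 to compound 3 (0.06 log units; within the scatter), that is, no movement beyond the usual scatter.

Compound 3 is therefore estimated at 4500 nM, with a range from 1500 nM to 13000 nM.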

Compound 3, concentration for total growth inhibition: 10300 nM
Beside the measured number, compound 3's estimate is 2.3-fold (0.36 log units) below it; the measured number falls inside the stated range.
By their numbers in this assay, from the lowest: compounds 1, 3 and 2 (each within the scatter of the next, the first and the last beyond it).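

In this assay, the urea aryl can be changed from 3,4-dichlorophenyl to 4-chloro-3-(trifluoromethyl)phenyl with a step that stays within the scatter (a 2.0-fold higher number from compound 1 to compound 3 (0.30 log units; within the scatter)). Replacing one heavy atom with four at this aromatic carbon, ortho to a chloro group, therefore gives no number that can be told apart from that of compound 1, whereas the step on the aromatic oxygen (a 2.4-fold higher number from compound 1 to compound 2 (0.37 log units; beyond the scatter)) lies beyond the scatter. No measurement at hand accounts for this result.

On these data alone, whether a nitrile, an amine or a carboxylic acid at this carbon would also stay within the scatter remains open. Also open, as far as these compounds go, is whether hydrogen in place of methyl on the aromatic oxygen would give a similar step on compound 3.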